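The compounds below may be only part of what the source reports. "The series", "measured", "known", "first", "only" and "open" are said of these compounds alone.

Measured so far:
Compound 1 `c1ccc(-c2ccoc2)c(OCC2=NCCN2)c1`, in a functional assay for activation of Alpha-1B adrenergic receptor (Homo sapiens), read by calcium flux; on this read-out lower numbers stand for an effect already at smaller amounts and higher numbers for an effect only at larger amounts of compound: 5.01 nM
Compound 2 `Cc1ccc(-c2ccccc2OCC2=NCCN2)s1`, in this assay: < 100000 nM, which is a limit of the assay and not a number.

Compound 2 therefore stands nowhere exact on the scale shown; only a limit is known for it, as noted in the limit of < 100000 nM in this assay, at which 1 of the 2 values shown sits. Among the measured compounds shown here, compound 1 has the one real number of the pair, and the change from it to compound 2 gives a step that the limit leaves unreadable from compound 1 to compound 2, because the value of compound 2 is a limit (the limit of < 100000 nM in this assay, at which 1 of the 2 values shown sits).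

The next compound, compound 3 `Cc1cnsc1-c1ccccc1OCC1=NCCN1`, differs from compound 2 in one place: 4-methyl-1,2-thiazol-5-yl in place of 5-methylthiophen-2-yl on an aromatic carbon. For the measured compounds named here, no measured step mirrors this exchange, and the only step that reaches compound 2 could not be read. The expectation for the step from compound 2 to compound 3 is therefore loose, set at a step that the limit leaves unreadable from compound 2 to compound 3, with no direction that the data support. Compound 3 is estimated at 3000 nM, within a wide range from 100 nM to 100000 nM, and a further limit instead of a number remains a real possibility.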

Compound 3, half-maximal effective concentration: < 100000 nM
Compound 3: a limit, no number; the forecaster's own chance of this, stated with the estimate: 40%; the middle value does not contradict the limit.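

In this assay compound 3 gives < 100000 nM, which is a limit of the assay and not a number. The steps to compound 3 from compound 1 and from compound 2 therefore cannot be read: the limit of < 100000 nM in this assay, at which 2 of the 3 values shown sit.

Left open is where compound 2 and compound 3 truly stand in this assay, and how their rings compare with the furan-3-yl of compound 1.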